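The source may hold more compounds than are shown below. What is called first, only, known or untested is meant among the compounds shown, and "the series" means these compounds.

Notes on the series. Three compounds built on the shared core of compound 1 `CC(C)=CCc1cc(C(=O)Nc2cc3ccc(OCC4CCN(C)C4)c(C)c3oc2=O)ccc1O` have numbers in a functional assay on MCF7 cells (Homo sapiens) for antiproliferative activity; a lower number here means a stronger inhibitor, a higher number a weaker inhibitor. Compound 1 gives 1550 nM, compound 2 `CC(C)=CCc1cc(C(=O)Nc2cc3ccc(OCCCN(C)C(C)(C)C)c(C)c3oc2=O)ccc1O` gives 1140 nM, and compound 3 `COC(=O)CNCCCOc1ccc2cc(NC(=O)c3ccc(O)c(CC=C(C)C)c3)c(=O)oc2c1C` gives 2820 nM. Compound 1 thus holds the second highest of the three numbers, though both its neighbours sit close: the nearest is compound 2, with a 1.4-fold lower number from compound 1 to compound 2 (0.13 log units; within the scatter), and the furthest is compound 3, with a 1.8-fold higher number from compound 1 to compound 3 (0.26 log units; within the scatter). Compound 4 `CC(C)=CCc1cc(C(=O)Nc2cc3ccc(OCCCNCC(N)=O)c(C)c3oc2=O)ccc1O` has not yet been measured. Relative to compound 1 the change is 2-((carbamoylmethyl)amino)ethyl in place of 1-methylpyrrolidin-3-yl on a saturated chain carbon bound to an oxygen on an aromatic ring. The step that bears most directly on it is a 1.8-fold higher number from compound 1 to compound 3 (0.26 log units; within the scatter), since compound 3 carries a chain of the same kind in the same place and differs from compound 4 only in an ester where compound 4 has an amide; the related step of a 2.5-fold higher number from compound 2 to compound 3 (0.39 log units; beyond the scatter) points the same way, from a chain amine to a chain amine bearing a carbonyl-containing group. On the strength of compound 3 and a 1.8-fold higher number from compound 1 to compound 3 (0.26 log units; within the scatter), the expectation for compound 4 is a small step to a higher number, a 1.6-fold higher number from compound 1 to compound 4 (0.21 log units; within the scatter), quite possibly within the scatter. The estimate for compound 4 in this assay is 2500 nM, with a range from 1200 nM to 5200 nM.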

Compound 4, half-maximal inhibitory concentration: 1460 nM
Beside the measured number, compound 4's estimate is 1.7-fold (0.23 log units) above it; measured number inside the range.
By their numbers in this assay, from the lowest: compounds 2, 4, 1 and 3 (each within the scatter of the next, the first and the last beyond it).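

Working notes. In this assay, the open-chain 2-((carbamoylmethyl)amino)ethyl group, which has no ring, can replace the ring-bearing 1-methylpyrrolidin-3-yl at this position without a change that can be told from the scatter (a 1.1-fold lower number from compound 1 to compound 4 (0.03 log units; within the scatter)). Amino in place of methoxy on a carbonyl carbon also stays within the scatter (a 1.9-fold lower number from compound 3 to compound 4 (0.29 log units; within the scatter)), as does (carbamoylmethyl)amino in place of methyl(tert-butyl)amino (a 1.3-fold higher number from compound 2 to compound 4 (0.11 log units; within the scatter)), so compound 4 cannot be separated from compound 2 or compound 3, even though those two lie apart (a 2.5-fold higher number from compound 2 to compound 3 (0.39 log units; beyond the scatter)). No measurement offered here bears on why these changes move the number so little.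

Going by these compounds, whether any group at this position can move the number well beyond the scatter stays open, since all four compounds lie in a narrow band in this one assay. A carboxylic acid in place of the amino on the carbonyl carbon, or a longer chain between the oxygen and the amine, would test how far that tolerance extends.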